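A few compounds are considered here, and "the series" means these few. Any claim that something is new, unique, unknown or untested is made for them only; others in the source may bear on it.

Compound 1 `O=C(O)CCCCC(CCSC(=O)c1ccccc1)SC(=O)c1ccccc1` gives 0.77% in a functional assay on NCI-H460 cells (Homo sapiens) for inhibition, read by MTT assay, with a stated time of 24 h, tested at 1 ug/mL (a lower number here means less inhibition of growth, a higher number more inhibition of growth at the concentration tested), and stands within the scatter of the two other measured compounds. Compound 2 `O=C(CCCCC1CCSS1)Nc1ccc(Cl)cn1` gives 6.26% there and compound 3 `O=C(CCCCC(S)CCS)Nc1ccc(Cl)cc1` gives 6.76% there, so none of the three can be ranked. All three sit near the bottom of the percentage scale at the concentration tested.

Compound 4 `O=C(CCCCC(CCSC(=O)c1ccccc1)SC(=O)c1ccccc1)Nc1ccccc1` keeps the core of compound 1 and differs in one place: anilino in place of hydroxy on a carbonyl carbon with anilino in place of hydroxy on a carbonyl carbon. Among the measured compounds shown here, no measured pair shows this change alone. For the measured compounds named here, compound 3 also carries a nitrogen-linked aromatic ring on a carbonyl carbon and gives 6.76% within the scatter of compound 1, which is the only indirect guide available.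

The step expected in this assay is small: a number 6.2 percentage points higher from compound 1 to compound 4 (within the scatter) is estimated to stay within the scatter, upward if anything. In this assay the estimate for compound 4 is 7% with an expected range from 1% to 20% for repeat measurements.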

Compound 4, percent growth inhibition at one concentration: 5.93%
For compound 4 the middle estimate is 1.1 percentage points above the measured one, and the stated range covers the measured number.
By their numbers in this assay, from the lowest: compounds 1, 4, 2 and 3 (each within the scatter of the next).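

Among the compounds shown here, the change of hydroxy to anilino on a carbonyl carbon appears here as a single change for the first time, and in this assay it gives a number 5.2 percentage points higher from compound 1 to compound 4 (within the scatter). At this position, therefore, the carboxy of compound 1 and the phenylcarbamoyl of compound 4 cannot be told apart, and a six-membered aromatic ring of carbon only can enter there with the number staying near the bottom of the percentage scale. Nothing available bears on why the two compounds read alike.

The compounds shown leave open whether a methyl ester or a benzylamino group on the same carbonyl carbon would also stay within the scatter of compound 1. They also leave open whether a chloro group on the anilino ring of compound 4 would change the number.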